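Methoxy to Chloro on Two Different Cores

The source may hold more compounds than are shown below. What is called first, only, known or untested is meant among the compounds shown, and "the series" means these compounds.

Measured so far:
compound 1 `COc1cccc(-c2cc(C(C)(C)C)cc(C(C)C)c2CO)c1` gives 200 nM
compound 2 `CC(C)c1cc(C(C)(C)C)cc(-c2cccc(Cl)c2)c1CO` gives 100 nM
compound 3 `COc1ccc(CCC(=O)Nc2sc3c(c2C#N)CCCC3)cc1` gives 410 nM

The three compounds were tested in a functional assay on RKE cells for antagonist activity at Vasoactive intestinal polypeptide receptor 1 (Rattus norvegicus), read by HTRF and cAMP accumulation, with stated times of 10 min and 30 min; a higher number here means a weaker inhibitor, a lower number a stronger inhibitor. Compounds 1 and 2 share one core and differ in a single group: chloro in place of methoxy on an aromatic carbon. That change produced a 2.0-fold lower number from compound 1 to compound 2 (0.30 log units; within the scatter). Compound 3 belongs to a different core; the difference between the two cores is not broken down here. Its number is the highest of the three, and its step to compound 1 is beyond the scatter.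

Compound 4 `N#Cc1c(NC(=O)CCc2ccc(Cl)cc2)sc2c1CCCC2` has not yet been measured. It differs from compound 3 as follows: chloro in place of methoxy on an aromatic carbon. This is the same kind of change as that from compound 1 to compound 2, but not the same, since in compound 2 the chloro stands meta to a large group and in compound 4 para to a large group.

Compound 4 is expected to give a 1.6-fold lower number from compound 3 to compound 4 (0.21 log units; within the scatter), because the same kind of change gave a 2.0-fold lower number from compound 1 to compound 2 (0.30 log units; within the scatter) in this assay. Compound 4 is therefore estimated at 250 nM, with a range from 100 nM to 600 nM.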

Compound 4, half-maximal inhibitory concentration: 1200 nM
Compound 4: the middle estimate sits 4.8-fold (0.68 log units) below what was measured, outside the stated range (above it).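

On the core of compound 3, the swap of methoxy for chloro in this assay gave a 2.9-fold higher number from compound 3 to compound 4 (0.47 log units; beyond the scatter), so 4-methoxyphenyl to 4-chlorophenyl made the number higher on this core, a step beyond the scatter. The same kind of change therefore did not carry over from one core to the other, and a step read on one core was a poor guide to the other: the same change on two cores in this assay, a 2.0-fold lower number (0.30 log units; within the scatter) from compound 1 to compound 2 and a 2.9-fold higher number (0.47 log units; beyond the scatter) from compound 3 to compound 4, 5.9-fold (0.77 log units) apart, beyond the scatter of two such steps This rests on a single pair per core, and it does not show whether the gap belongs to the cores themselves or to where the chloro stands on each, nor does it give any reason for the gap.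

The compounds shown leave open how a fluoro, methyl or hydroxyl group would read in this assay in place of the methoxy of compound 3. They also leave open whether a longer chain between the amide carbonyl and the aromatic ring would change the effect of the chloro.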